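Dropping the Chloro Group: Estimating Compound 4

The compounds below may be only part of what the source reports. "The series", "measured", "known", "first", "only" and "open" are said of these compounds alone.

The three measured compounds and their values:
Compound 1 `CCCc1nc(-c2ccccc2)c(CNCCN2CCN(c3ccc(Cl)cc3)CC2)o1` gives 55.8%
Compound 2 `CCCc1nc(-c2ccccc2)c(CNCCCN2CCN(c3cccc(C(F)(F)F)c3)CC2)o1` gives 51.6%
Compound 3 `Cc1nc(-c2ccccc2)c(CNCCCN2CCN(c3ccc(Cl)cc3)CC2)o1` gives 38.1%

In an assay on HEK293 cells for inhibition of Voltage-dependent T-type calcium channel subunit alpha-1G (Homo sapiens), read by fluorescence, tested at 10 uM (a lower number here means less inhibition, a higher number more inhibition at the concentration tested (going by the name of the read-out)), compound 1 stands highest of the three numbers. Its nearest neighbour is compound 2, whose value lies within the usual scatter of compound 1, so no order between the two can be claimed. Compound 3 lies furthest away, beyond the scatter, with a clearly lower number.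

Compound 4 `CCCc1nc(-c2ccccc2)c(CNCCN2CCN(c3ccccc3)CC2)o1` has not yet been measured in this assay. It differs from compound 1 in a single place: hydrogen in place of chloro on an aromatic carbon. Going by the values given here, no measured pair in this set shows that exact change, so there is no directly comparable step to lean on.

Taking compound 1 as the starting point, a modest downward step is expected, with a fair chance of none beyond the scatter. The step from compound 1 to compound 4 is expected to be about a number 9.8 percentage points lower from compound 1 to compound 4 (within the scatter). Compound 4 is therefore estimated to give about 46%, in a range from 28% to 62%.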

Compound 4, a percentage reported as inhibition, at one concentration (the size of the read-out at that concentration, not a potency): 54.3%
The estimate for compound 4 lay 8.3 percentage points below the measured number, and the stated range covers the measured number.
By their numbers in this assay, from the lowest: compound 3; then compounds 2, 4 and 1 (each within the scatter of the next).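

In this assay, the change from 4-chlorophenyl to phenyl gives a number 1.5 percentage points lower from compound 1 to compound 4 (within the scatter). Going by these compounds alone, this is the first direct look at this position: for this one pair, the chloro group can be replaced by hydrogen with no change that stands out from the scatter, so the inhibition seen at the tested concentration does not depend on that chlorine. The read-out comes from one concentration and is not a potency, and nothing available explains the result.

The compounds shown leave open whether a larger or differently charged group at this place, such as a methoxy group, an amine or a carboxylic acid, would move the number beyond the scatter. They also leave open whether hydrogen in place of chloro would give as small a step on compound 3, which carries a methyl group on the shared core.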